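Trimethoxy Variant of a Chalcone-Macrolactam Conjugate

The source may report more compounds than this note shows. Statements on the series, on what has been measured and on what is new or still open speak of the compounds shown alone.

For the measured compounds named here, compound 2 `COc1cccc(/C=C/C(=O)c2ccc(OCCCN3C(=O)/C=C/C(C)(C)C/C=C(\C)CC/C=C/3C)cc2)c1` is one of two compounds measured in a functional assay on P338 cells (Mus musculus) for antiproliferative activity (on this read-out lower numbers stand for stronger inhibition and higher numbers for weaker inhibition), where compound 2 gives 1.1 ug/mL. Compound 1 `C/C1=C\CC(C)(C)/C=C/C(=O)N(Cc2cn(CCOc3ccc(C(=O)/C=C/c4ccc(C)cc4)c(O)c3)nn2)/C(C)=C/CC1` gives 0.92 ug/mL in this assay; the two numbers lie within the scatter of each other, with compound 2 holding the higher of the two. Compound 3 `COc1cc(/C=C/C(=O)c2ccc(OCCCN3C(=O)/C=C/C(C)(C)C/C=C(\C)CC/C=C/3C)cc2)cc(OC)c1OC` has not yet been measured. It differs from compound 2 in one place: 3,4,5-trimethoxyphenyl in place of 3-methoxyphenyl on a double-bonded chain carbon bound to a double-bonded chain carbon. Going by the values given here, no pair of measured compounds shows this change, so the size of the step it brings cannot be read from the data. With only these two numbers to go on, the step is expected to be small, not beyond the scatter, in either direction, and the expected step is a 1.2-fold lower number from compound 2 to compound 3 (0.09 log units; within the scatter). Compound 3 is therefore estimated at 0.9 ug/mL in this assay, within a range from 0.35 ug/mL to 2.5 ug/mL.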

Compound 3, half-maximal inhibitory concentration: 0.77 ug/mL
Compound 3: the middle estimate sits 1.2-fold (0.07 log units) above what was measured, and the stated range covers the measured number.
By their numbers in this assay, from the lowest: compounds 3, 1 and 2 (each within the scatter of the next).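

In this assay, 3,4,5-trimethoxyphenyl in place of 3-methoxyphenyl on a double-bonded chain carbon bound to a double-bonded chain carbon gives a 1.4-fold lower number from compound 2 to compound 3 (0.15 log units; within the scatter). For the compounds shown here, this is the first reading of any change at this position, and it shows that the position accepts the larger group, with 12 heavy atoms and 3 hydrogen-bond acceptors against 8 and 1, with no step beyond the scatter. Nothing in the data offers an explanation for this result.

The compounds shown leave open whether a group of another kind at this position, such as an amine or a carboxylic acid in place of the methoxy groups, would bring a step beyond the scatter. They also leave open whether the same exchange would give a similar step on the core of compound 1.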